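The compounds below may be only part of what the source reports. "The series", "measured", "known", "first", "only" and "open" are said of these compounds alone.

Measured in a functional assay on MGC-803 cells (Homo sapiens) for inhibition, read by MTT assay, with a stated time of 48 h (a higher number here means a weaker inhibitor, a lower number a stronger inhibitor), so far:
- compound 1 `COc1ccc(CN(C(=O)C(C)Br)c2cc(OC)c(OC)c(OC)c2)cc1O` gives 120 nM
- compound 2 `C/C=C/C(=O)N(Cc1cc(OC)c(OC)c(OC)c1)c1ccc(OC)c(O)c1` gives 6150 nM
- compound 3 `COC(=O)c1cc(CNc2cc(OC)c(OC)c(OC)c2)ccc1OC` gives 49600 nM

Compound 1 holds the lowest of the three numbers, and its gaps to compound 2 and to compound 3 both lie beyond the scatter of repeated measurements. Compound 4 `COc1ccc(CN(C(=O)CN=[N+]=[N-])c2cc(OC)c(OC)c(OC)c2)cc1O` has not yet been measured. It keeps the core of compound 1 but carries azidomethyl in place of 1-bromoethyl on a carbonyl carbon. Within the data shown here, no step between measured compounds isolates a change of this kind, so the data give no direct guide. The values do span a wide range, from compound 1 at 120 nM to compound 3 at 49600 nM, which leaves room for a sizeable move. Since compound 1 already stands lowest, a moderate rise in the number is expected, with an estimated 4.2-fold higher number from compound 1 to compound 4 (0.62 log units; beyond the scatter) as the likely outcome. For compound 4 the expected value is 500 nM, with an estimated range from 80 nM to 3500 nM.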

Compound 4, half-maximal inhibitory concentration: 120 nM
Compound 4: middle estimate off by 4.2-fold (0.62 log units), on the high side; measured number inside the range.
By their numbers in this assay, from the lowest: compounds 1 and 4 (each within the scatter of the next); then compound 2; then compound 3.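

In this assay, among these compounds, the first single-place comparison reads no change at the digits printed from compound 1 to compound 4 (within the scatter) for azidomethyl in place of 1-bromoethyl on the carbonyl carbon whose other neighbour is the amide-type nitrogen. Compounds 2 and 3 differ from compound 1 in more than one place, so they could not show this. The pair now shows that, on the core of compound 1, this carbonyl carbon can carry a group without bromine and the two compounds stand level. No measurement shown explains why the two groups read alike. Still open, from the compounds shown here alone, is whether an aminomethyl group, a chloromethyl group or a longer chain on the same carbonyl carbon would keep this level. Also open, going by these compounds, is whether azidomethyl would read the same way on a different core.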